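Swapping Methoxy for Fluoro in a Small Series

The source may hold more compounds than are shown below. What is called first, only, known or untested is meant among the compounds shown, and "the series" means these compounds.

Of the compounds shown here, three have been measured in a functional assay on A549 cells (Homo sapiens) for antiproliferative activity, read by MTT assay; a higher number here means a weaker inhibitor, a lower number a stronger inhibitor. Compound 1 (`COc1ccc(-c2ccnc(Nc3ccc([N+](=O)[O-])cc3)n2)cc1`) gives 2730 nM, the lowest of the three numbers, which makes it the strongest inhibitor so far. Compound 3 (`COc1cccc(Nc2nccc(-c3ccc(Cl)c(Cl)c3)n2)c1`) gives 6000 nM and compound 2 (`Clc1ccc(Nc2nccc(-c3ccc(Cl)cc3Cl)n2)c(Cl)c1`) gives 11600 nM, both higher than compound 1 by more than the usual scatter.

Compound 4 (`O=[N+]([O-])c1ccc(Nc2nccc(-c3ccc(F)cc3)n2)cc1`) differs from compound 1 in one place, with fluoro in place of methoxy on an aromatic carbon, para to a large group: fluoro in place of methoxy on an aromatic carbon. The same difference reads as 4-methoxyphenyl to 4-fluorophenyl.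

Within the data shown here, no measured pair isolates this change, so the evidence is thin. Among the measured compounds shown here, compound 1 is the only measured compound with the 4-methoxyphenyl group and the nitro group, and it gives 2730 nM. Compound 4 loses the first and keeps the second. A modest rise in the number is therefore expected, a 2.2-fold higher number from compound 1 to compound 4 (0.34 log units; beyond the scatter). For compound 4 the estimated value is 6000 nM, with an expected range of 2000 nM to 18000 nM.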

Compound 4, half-maximal inhibitory concentration: 84000 nM
Beside the measured number, compound 4's estimate is 14-fold (1.15 log units) below it; the whole stated range lies below it.
By their numbers in this assay, from the lowest: compound 1; then compounds 3 and 2 (each within the scatter of the next); then compound 4.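

In this assay, replacing methoxy with fluoro on an aromatic carbon, para to a large group, gives a 31-fold higher number from compound 1 to compound 4 (1.49 log units; beyond the scatter), a large step that shows how strongly the number depends on the group at this position. Among these compounds, this is the first pair to differ in one place only, whereas the earlier compounds differ in several places at once and could not separate the weight of any single group. No measurement on hand explains the size of this step.

One pair cannot tell whether the rise follows from methoxy leaving or fluoro entering, so an ethoxy, a hydroxy or an amine at the same position would help separate the two. From the compounds shown here alone, it also remains open whether the same swap gives a step of similar size when the nitro group of compound 1 is replaced by another group.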